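Swapping the biaryl tail for a methoxyphenyl ether

This account rests on a few compounds, and the source may have more. Where it says the series, first, only, none or still open, it means among the compounds named here.

Compound 1 `COc1cccc(CNCCCNc2ccnc3cc(-c4ccc(C(C)(C)C)cc4)ccc23)c1O`: 32000 nM
Compound 2 `COc1cccc(Oc2ccc3c(NCCCNCc4ccco4)ccnc3c2)c1`: 14500 nM
Compound 3 `CC(C)(C)c1ccc(-c2ccc3c(NCCCNCc4ccco4)ccnc3c2)cc1`: 32000 nM

In a physicochemical assay for solubility, with a stated time of 18 h, at pH 7.4 (a lower number here means a less soluble compound, a higher number a more soluble compound), compound 3 stands level with compound 1, the two together giving the highest numbers, while compound 2 sits lower. Compound 4 `COc1ccc(Oc2ccc3c(NCCCNCc4ccco4)ccnc3c2)cc1` differs from compound 3 in one place: 4-methoxyphenoxy in place of 4-(tert-butyl)phenyl on an aromatic carbon. Within the data shown here, the one measured step that bears on this is a 2.2-fold higher number from compound 2 to compound 3 (0.34 log units; beyond the scatter), and compound 4 carries a group close to that of compound 2. Running that step backwards, a modest fall in this assay is expected for compound 4, of about a 2.1-fold lower number from compound 3 to compound 4 (0.33 log units; beyond the scatter). Compound 4 is therefore estimated at 15000 nM, in the range 7000 nM to 32000 nM.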

Compound 4, solubility: 14500 nM
For compound 4 the middle estimate is 1.0-fold (0.01 log units) above the measured one, within the range that was stated.
By their numbers in this assay, from the lowest: compounds 2 and 4 (each within the scatter of the next); then compounds 1 and 3 (each within the scatter of the next).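

In this assay, 4-methoxyphenoxy in place of 4-(tert-butyl)phenyl gives a 2.2-fold lower number from compound 3 to compound 4 (0.34 log units; beyond the scatter) in a second ether, so the earlier drop seen with compound 2 is not confined to a single ether. 4-methoxyphenyl in place of 3-methoxyphenyl on the oxygen gives no change at the digits printed from compound 2 to compound 4 (within the scatter) and thus no separation between these two ethers. No measurement shown explains the difference between the ethers and the tert-butyl biaryl. Still open, from the compounds shown here alone, is whether the drop follows the oxygen link or the ring substituent, which a directly attached 4-methoxyphenyl group would help to separate.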